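Replacing 4-ethoxyphenyl with 3-chlorophenyl

This account rests on a few compounds, and the source may have more. Where it says the series, first, only, none or still open, it means among the compounds named here.

Compound 1 (`COc1ccc(/C=C/[C@@](C)(/C=C/c2ccc(O)c(C=O)c2)CCC=C(C)C)cc1`) gives 9800 nM
Compound 2 (`CCOc1ccc(/C=C/[C@@](C)(/C=C/c2ccc(O)cc2)CCC=C(C)C)cc1`) gives > 36600 nM (a limit)

In an ADME assay on BJ cells (Homo sapiens) for cytotoxicity, with a stated time of 72 h (a lower number here means that less compound is needed, a higher number that more compound is needed for the effect), compound 2 stands at a limit (> 36600 nM) and has no number. Compound 3 (`CC(C)=CCC[C@](C)(/C=C/c1ccc(O)cc1)/C=C/c1cccc(Cl)c1`) carries 3-chlorophenyl in place of 4-ethoxyphenyl on a double-bonded chain carbon bound to a double-bonded chain carbon and remains unmeasured. No measured step sizes this change. Among the compounds with values here, compound 1 (9800 nM) shows only that a number can be reached in this assay. A modest move toward a lower number is expected, and a second limit remains possible. The expected step is an at least 1.6-fold lower number from compound 2 to compound 3 (0.22 log units; that floor lies within the scatter) and it is uncertain. Compound 3 is estimated at 22000 nM (9000 nM to 50000 nM).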

Compound 3, half-maximal effective concentration: > 36600 nM
Compound 3 ended at the assay's limit (the forecaster's own chance of this, stated with the estimate: 40%); middle value at least 1.6-fold (0.22 log units) from the limit.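

No step can be read from compound 2 to compound 3, because both compounds stand at a limit and neither gives a number: the limit of > 36600 nM in this assay, at which 2 of the 3 values shown sit. The compounds shown leave open whether 3-chlorophenyl in place of 4-ethoxyphenyl changes the value at all.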